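From phenyl to 4-hydroxyphenyl in compound 3

This account rests on a few compounds, and the source may have more. Where it says the series, first, only, none or still open, it means among the compounds named here.

Compound 1 `O=C(Cc1csc2nc(-c3ccc(Br)cc3)cn12)N/N=C/c1ccccc1` and compound 2 `O=C(Cc1csc2nc(-c3ccc(Br)cc3)cn12)N/N=C/c1ccccc1O` share one core and have both been measured in a functional assay on SF-539 cells (Homo sapiens) for inhibition, read by sulforhodamine B assay, with a stated time of 48 h; on this read-out higher numbers stand for weaker inhibition of growth and lower numbers for stronger inhibition of growth. Compound 1 gives 39800 nM, the higher of the two numbers and so the weaker inhibition of growth. Compound 2 gives 11700 nM. The open question concerns compound 3 `O=C(Cc1csc2nc(-c3ccc(Br)cc3)cn12)N/N=C/c1ccc(O)cc1`, which has not yet been measured. It differs from compound 1 by hydroxy in place of hydrogen on an aromatic carbon, a hydroxy in place of hydrogen on an aromatic carbon, para to a large group, turning phenyl into 4-hydroxyphenyl.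

Among the compounds with values here, only one measured step bears on this change: a 3.4-fold lower number from compound 1 to compound 2 (0.53 log units; beyond the scatter). It is the same exchange of hydrogen for hydroxy, made at a different aromatic carbon, so it offers a guide to direction but a looser one to size. With this single precedent, a modest move towards a lower number in this assay is expected, probably smaller than the step to compound 2. The expected step is a 2.2-fold lower number from compound 1 to compound 3 (0.34 log units; beyond the scatter). Compound 3 is estimated to read 18000 nM, with an expected range of 7000 nM to 45000 nM.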

Compound 3, concentration for total growth inhibition: 46800 nM
Beside the measured number, compound 3's estimate is 2.6-fold (0.41 log units) below it, outside the stated range (above it).
By their numbers in this assay, from the lowest: compound 2; then compounds 1 and 3 (each within the scatter of the next).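

In this assay, hydroxy in place of hydrogen on an aromatic carbon, para to a large group, gives a 1.2-fold higher number from compound 1 to compound 3 (0.07 log units; within the scatter) and so leaves the reading of the parent phenyl compound unchanged within the usual scatter. The same exchange therefore does not act alike at every carbon of this ring, for the lower number of compound 2 does not carry over to the 4-hydroxyphenyl isomer, as the move of the hydroxy shows with a 4.0-fold higher number from compound 2 to compound 3 (0.60 log units; beyond the scatter) in the same assay. Of the three compounds, only compound 2 stands apart from the others, and nothing available here explains why the two places differ.

As far as these compounds go, what remains open is whether the lower number of compound 2 depends on the hydroxy itself, which a methoxy group or an amine on that same carbon of the 2-hydroxyphenyl ring would help to settle. From the compounds shown here alone, it is also open whether the difference between the 2-hydroxyphenyl and 4-hydroxyphenyl compounds would persist with chlorine in place of the bromine on the shared core.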